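A Methyl Group on the Shared Core, Twice Over

The source may report more compounds than this note shows. Statements on the series, on what has been measured and on what is new or still open speak of the compounds shown alone.

Compound 1, with the structure `COCOc1ccccc1-c1cc2ccccc2c(=O)[nH]1`, was tested in a functional assay on A549 cells (Homo sapiens) for cytotoxicity, read by sulforhodamine B assay (a lower number here means a stronger inhibitor, a higher number a weaker inhibitor), where compound 1 gives 23600 nM. Compound 2, with the structure `COCOc1ccccc1-c1cc2cc(C)ccc2c(=O)[nH]1`, carries one added group on the shared core. In this assay compound 2 gives > 100000 nM, which is a limit of the assay rather than a number. The change between them is methyl in place of hydrogen on an aromatic carbon, and it brought an at least 4.2-fold higher number from compound 1 to compound 2 (0.62 log units; beyond the scatter).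

Compound 3, with the structure `C=COc1ccccc1-c1c(Br)c2ccccc2c(=O)n1Cc1ccc(OC)cc1`, has a different core; how the core of compound 3 differs from the core of compound 1 is not broken down here. In this assay compound 3 gives > 100000 nM, again a limit of the assay rather than a number.

Compound 4, with the structure `C=COc1ccccc1-c1c(Br)c2cc(C)ccc2c(=O)n1Cc1ccc(OC)cc1`, is not yet measured. For the measured compounds named here, it differs from compound 3 by methyl in place of hydrogen on an aromatic carbon, which is the same change as the one from compound 1 to compound 2, at a place described in the same words. Because compound 3 already sits at the limit of > 100000 nM in this assay, at which 2 of the 3 values shown sit, and the earlier step of an at least 4.2-fold higher number from compound 1 to compound 2 (0.62 log units; beyond the scatter) moved the number upward, the expected step is a step that the limit leaves unreadable from compound 3 to compound 4. For compound 4 the expected value in this assay is 200000 nM, with an expected range from 100000 nM to 1000000 nM, most likely reported only as a limit.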

Compound 4, half-maximal inhibitory concentration: 67800 nM
The estimate for compound 4 lay 2.9-fold (0.47 log units) above the measured number, outside the stated range (below it).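

In this assay, methyl in place of hydrogen on an aromatic carbon did not carry over from one core to the other as the same step, and the two cores answered in opposite directions: the same change on two cores in this assay, an at least 4.2-fold higher number (0.62 log units; beyond the scatter) from compound 1 to compound 2 and an at least 1.4-fold lower number (0.16 log units; that floor lies within the scatter) from compound 3 to compound 4, at least 6.2-fold (0.79 log units) apart, beyond the scatter of two such steps

Taken alone, the new result is an at least 1.4-fold lower number from compound 3 to compound 4 (0.16 log units; that floor lies within the scatter), and this is only a floor on the true step, since one end of it is a limit of the assay and not a number. What this does not show is which difference between the two cores separates the outcomes, or how the same methyl would behave on any third core, and two pairs of compounds cannot establish a rule for the series.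

The compounds shown leave open whether another group on this same aromatic carbon, such as a chlorine atom, a methoxy group or an amine, would also give opposite steps on the two cores. Also open, as far as these compounds go, is the true size of each of the two steps, both of which rest on a limit of the assay.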